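Compound 2 to compound 4: one side group removed

A few compounds are considered here, and "the series" means these few. Any claim that something is new, unique, unknown or untested is made for them only; others in the source may bear on it.

Compound 1 `COc1cc(/C=C/C(=O)/C=C(O)/C=C/c2ccc(OC(=O)C(C)(CO)CO)c(OC)c2)ccc1OC(=O)C(C)(CO)CO` gives 3910 nM
Compound 2 `CCC(CO)(CO)C(=O)Oc1ccc(/C=C/C(=O)/C=C(O)/C=C/c2ccc(OC(=O)C(CC)(CO)CO)c(OC)c2)cc1OC` gives 1340 nM
Compound 3 `COc1cc(/C=C/C(O)=C/C(=O)/C=C/c2ccc(OC(=O)C(C)(CO)CO)c(OC)c2)ccc1O` gives 15500 nM

These numbers come from a functional assay on HCT-116 cells (Homo sapiens) for antiproliferative activity, read by MTT assay, with a stated time of 72 h (a higher number here means a weaker inhibitor, a lower number a stronger inhibitor), and they place compound 2 lowest of the three, which makes it the strongest inhibitor here, with both gaps beyond the usual scatter. Compound 4 `CCC(CO)(CO)C(=O)Oc1ccc(/C=C/C(=O)/C=C(O)/C=C/c2ccc(O)c(OC)c2)cc1OC` has not yet been measured. It arises from compound 2 through hydrogen in place of (1,1-bis(hydroxymethyl)propyl)carbonyl on an oxygen on an aromatic ring and this means hydrogen in place of (1,1-bis(hydroxymethyl)propyl)carbonyl on an oxygen on an aromatic ring.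

Among the measured compounds shown here, only one measured step bears on this. The closest parallel is a 4.0-fold higher number from compound 1 to compound 3 (0.60 log units; beyond the scatter) and it came from hydrogen in place of (1,1-bis(hydroxymethyl)ethyl)carbonyl on an oxygen on an aromatic ring. The group removed there carries a shorter name but is otherwise alike, though a single example is thin support. A similar loss of strength is therefore expected, as an estimated 4.0-fold higher number from compound 2 to compound 4 (0.61 log units; beyond the scatter) in the same direction. The estimated value for compound 4 is 5400 nM (expected range 2400 nM to 12000 nM).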

Compound 4, half-maximal inhibitory concentration: 11400 nM
Estimate against measurement, compound 4: 2.1-fold (0.32 log units) below; the measured number falls inside the stated range.
By their numbers in this assay, from the lowest: compound 2; then compound 1; then compounds 4 and 3 (each within the scatter of the next).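

In this assay, the second removal of an ester from an oxygen on an aromatic ring, replacing (1,1-bis(hydroxymethyl)propyl)carbonyl with hydrogen, gives an 8.5-fold higher number from compound 2 to compound 4 (0.93 log units; beyond the scatter) and goes the same way as a 4.0-fold higher number from compound 1 to compound 3 (0.60 log units; beyond the scatter), so the loss of strength now appears in two matched pairs rather than one. With one ester gone, the extra methyl on the chain of the ester that remains is not resolved, at a 1.4-fold lower number from compound 3 to compound 4 (0.13 log units; within the scatter). No measurement shown explains why removing this group weakens the compounds.

As far as these compounds go, whether the free hydroxy matters, or only the absence of the ester, remains open, and a plain methyl ether on that oxygen would help separate the two. Also open, from the compounds shown here alone, is how a longer chain such as butyl, or an amine on the ester chain, would compare.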